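The compounds below may be only part of what the source reports. "The series", "measured", "known", "first", "only" and "open" are said of these compounds alone.

Compound 3, with the structure `O=c1nc2occc2cn1COCCO`, is the bare core of this small set. In a functional assay on HEL cells (Homo sapiens) (on this read-out lower numbers stand for higher toxicity in this test and higher numbers for lower toxicity in this test), compound 3 gives only a limit, > 200000 nM, so its true number is not known. Two related compounds carry a chain on the same core. Compound 1, `CCCCCCCCC#Cc1cc2cn(COCCO)c(=O)nc2o1`, gives 42000 nM in this assay. Compound 2, `CCCCCC#Cc1cc2cn(COCCO)c(=O)nc2o1`, gives a limit of > 50000 nM in this assay. The shortening of the chain gives an at least 1.1-fold higher number from compound 1 to compound 2 (0.07 log units; that floor lies within the scatter). Removing the whole chain gives a step that the two limits leave unreadable from compound 2 to compound 3, a step whose size cannot be read, since both ends are limits; this is noted at the limit of > 200000 nM in this assay, at which 1 of the 3 values shown sits, and (the limit of > 50000 nM in this assay, at which 1 of the 3 values shown sits).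

Compound 4, `CCCCC#Cc1cc2cn(COCCO)c(=O)nc2o1`, is the next step from compound 3: hex-1-yn-1-yl in place of hydrogen on an aromatic carbon. The change runs opposite to the shortening seen between compound 1 and compound 2, and it adds a chain one carbon shorter than that of compound 2. Among the measured compounds shown here, no measured step gives a readable size for this kind of change, so only a rough expectation is possible: a small shift toward the numbers of compound 2, with a good chance that this assay again reports only a limit. The expected step is an at least 2.0-fold lower number from compound 3 to compound 4 (0.30 log units; that floor lies within the scatter). For compound 4 the estimated half-maximal cytotoxic concentration is 100000 nM, with a range from 40000 nM to 250000 nM.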

Compound 4, half-maximal cytotoxic concentration: > 50000 nM
Compound 4: a limit, no number; the forecaster's own chance of this, stated with the estimate: 60%; the middle value lies beyond the limit too.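

Compound 4 shows that a hex-1-yn-1-yl chain on the aromatic carbon next to the ring oxygen still gives only a limit in this assay, the same limit as for compound 2, so the gain from a third chain length is no measured number: the limit of > 50000 nM in this assay, at which 2 of the 4 values shown sit.

Among the compounds shown here, measured against the only compound here with a true number, hydrogen in place of butyl on the chain gives an at least 1.1-fold higher number from compound 1 to compound 4 (0.07 log units; that floor lies within the scatter), so this step does not establish a real difference. Both ends are limits for the steps from compound 3 to compound 4 and from compound 2 to compound 4, and neither step can be read.

The compounds shown leave open how far the bare core and the two shorter chains truly differ in this assay, as none of the three has a number. Also open, as far as these compounds go, is what a chain longer than that of compound 1, or a chain ending in an amine or a carboxylic acid, would give at this carbon.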